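Solubility of compound 2 and a ring swap

A few compounds are considered here, and "the series" means these few. Any claim that something is new, unique, unknown or untested is made for them only; others in the source may bear on it.

- compound 1 (`Cc1ccoc1C(=O)N1CCC(NC(=O)Nc2ccc(C(F)(F)F)cc2)CC1`) measured at 1.8 ug/mL 
- compound 2 (`Cc1ccoc1C(=O)N1CCC(NC(=O)Nc2ccc(OC(F)(F)F)cc2)CC1`) measured at 3.4 ug/mL 

Going by the values given here, in a physicochemical assay for solubility, read by mass spectrometry, in phosphate buffer, with a stated time of 24 h, at pH 3 (on this read-out lower numbers stand for lower solubility and higher numbers for higher solubility), compound 2 reads 3.4 ug/mL and has only one measured neighbour. Compound 3 (`O=C(Nc1ccc(OC(F)(F)F)cc1)NC1CCN(C(=O)C2=COCC2)CC1`) differs from compound 2 by a group of 5 heavy atoms (4 carbon, 1 oxygen; one five-membered non-aromatic ring with 1 hetero atom) in place of a group of 6 heavy atoms (5 carbon, 1 oxygen; one five-membered aromatic ring with 1 hetero atom), on a carbonyl carbon and so trades the 3-methylfuran-2-yl group, with its five-membered aromatic ring, for a five-membered non-aromatic ring. Among the compounds with values here, no measured step touches this group on the carbonyl carbon, so no size can be carried over directly. Within the data shown here, the only measured step is a 1.9-fold higher number from compound 1 to compound 2 (0.28 log units; within the scatter) and it concerns trifluoromethoxy in place of trifluoromethyl on an aromatic carbon, a different change. With so little to go on, no shift beyond the scatter is expected in either direction, and the expected step is a 1.2-fold higher number from compound 2 to compound 3 (0.07 log units; within the scatter) with wide uncertainty. For compound 3 the estimate is 4 ug/mL with a range of 1.3 ug/mL to 12 ug/mL as the expected spread.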

Compound 3, solubility: 73 ug/mL
Estimate against measurement, compound 3: 18-fold (1.26 log units) below; measured number outside the range, above it.
By their numbers in this assay, from the lowest: compounds 1 and 2 (each within the scatter of the next); then compound 3.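

In this assay, the group on the carbonyl carbon proves to be a place where the number can move a long way: the swap of the 3-methylfuran-2-yl group for the non-aromatic ring gives a 21-fold higher number from compound 2 to compound 3 (1.33 log units; beyond the scatter). Going by these compounds alone, the only earlier step, a 1.9-fold higher number from compound 1 to compound 2 (0.28 log units; within the scatter), concerned the other end of the molecule and stayed within the scatter, so compound 3 is the first sign of a change that clearly exceeds it. No measurement at hand explains the size of this step.

The swap alters the size of the group and the aromatic character of its ring together, so the compounds shown cannot separate the two. From the compounds shown here alone, it also remains open how the number would respond to a ring carrying an amine or a carboxylic acid on this carbonyl carbon, or to the same swap with trifluoromethyl in place of trifluoromethoxy.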